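Swapping a piperidine for an anilino group on the core

The source may report more compounds than this note shows. Statements on the series, on what has been measured and on what is new or still open speak of the compounds shown alone.

Measured compounds and their values:
- compound 1, `CC1CCN(c2nc(Cl)nc3c2ncn3Cc2ccc(/C=C/C(=O)Nc3ccccc3N)cc2)CC1`: 8.24%
- compound 2, `Nc1ccccc1NC(=O)c1ccc(Cn2cnc3c(Nc4ccccc4)nc(Cl)nc32)cc1`: 42.7%
- compound 3, `CC(C)n1cnc2c(Nc3cccc(Cl)c3)nc(NCOCc3ccc(C(=O)Nc4ccccc4N)cc3)nc21`: 28.9%

These three compounds were tested in a functional assay on NCI-H460 cells (Homo sapiens) for antiproliferative activity, read by CCK-8 assay, with a stated time of 72 h, tested at 2 uM; a lower number here means a weaker effect, a higher number a stronger effect of the compound at the concentration tested. Compound 1 gives the lowest of the three numbers, at 8.24%; compound 3 lies above it by a gap beyond the scatter, and compound 2 lies further above it by a larger gap, also beyond the scatter.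

The next compound, compound 4 `Nc1ccccc1NC(=O)/C=C/c1ccc(Cn2cnc3c(Nc4cccc(OC(F)(F)F)c4)nc(Cl)nc32)cc1`, has not yet been measured in this assay. It departs from compound 1 in one place: (3-(trifluoromethoxy)phenyl)amino in place of 4-methylpiperidin-1-yl on an aromatic carbon. Going by the values given here, no pair of measured compounds differs in one place only, so no measured step tells directly how large this kind of change is.

Still, a step upward is expected from compound 1 to compound 4, because compound 2 gives 42.7% and compound 3 gives 28.9%, both carrying a phenylamino group rather than a piperidine at that place. The expected step of a number 21.8 percentage points higher from compound 1 to compound 4 (beyond the scatter) would lift compound 4 well beyond the scatter. Compound 4 is therefore estimated at 30%, with a range from 10% to 55%, though the measurement will decide.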

Compound 4, a percentage reported as inhibition, at one concentration (the size of the read-out at that concentration, not a potency): 2.1%
For compound 4 the middle estimate is 27.9 percentage points above the measured one, outside the stated range (below it).
By their numbers in this assay, from the lowest: compounds 4 and 1 (each within the scatter of the next); then compound 3; then compound 2.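

In this assay, going by these compounds alone, the first measured change at this position on the core gives a number 6.1 percentage points lower from compound 1 to compound 4 (within the scatter), so replacing 4-methylpiperidin-1-yl with (3-(trifluoromethoxy)phenyl)amino has no effect that can be told apart from the scatter. With the rest of compound 1 held fixed, this swap from a non-aromatic ring to an aromatic ring, which adds a hydrogen-bond donor and more heavy atoms, is therefore not enough on its own to raise the number. Nothing measured here explains why the swap changes so little.

As far as these compounds go, it remains open whether a plain phenylamino group without the trifluoromethoxy group would behave differently on this same molecule. A morpholine or a small amine such as dimethylamino at this place could also show whether any group here can shift the number beyond the scatter.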